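Chloro for methyl on an aryl ring of two amide cores

The compounds below may be only part of what the source reports. "The series", "measured", "known", "first", "only" and "open" are said of these compounds alone.

Compound 1 `Cc1cccc(-c2noc(C3CN(C(=O)C4CCC(C(F)(F)F)CC4)C3)n2)c1` in an assay on HEK293 cells for negative allosteric modulation of metabotropic glutamate receptor 5 (Homo sapiens), read by FLIPR (on this read-out lower numbers stand for stronger inhibition and higher numbers for weaker inhibition), gives > 10000 nM, a limit of the assay rather than a number. Compound 2 `O=C(C1CCC(C(F)(F)F)CC1)N1CC(c2nc(-c3cccc(Cl)c3)no2)C1` in this assay gives > 10000 nM, again a limit of the assay. For the measured compounds named here, compound 3 `Cc1cccc(-c2noc(C3CN(C(=O)c4ccccc4F)C3)n2)c1` in this assay gives 1400 nM, the only number among the three.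

Compound 4 `O=C(c1ccccc1F)N1CC(c2nc(-c3cccc(Cl)c3)no2)C1` has not been measured. It arises from compound 3 by the change (chloro in place of methyl on an aromatic carbon), and the same change, made on the core of compound 1, leads to compound 2: chloro in place of methyl on an aromatic carbon. The two cores themselves differ in a way that is not broken down here. The step that the two limits leave unreadable from compound 1 to compound 2 cannot be read, because both values sit at the limit of > 10000 nM in this assay, at which 2 of the 3 values shown sit. Compound 3 stands apart with the only number shown.

Going by the values given here, since the one measured instance of this change gives no readable size, the expectation for compound 4 rests mainly on compound 3 and its value 1400 nM, and compound 4 is estimated near it with a wide band: 1500 nM, between 400 nM and 6000 nM. The expected step of a 1.1-fold higher number from compound 3 to compound 4 (0.03 log units; within the scatter) is accordingly small.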

Compound 4, half-maximal inhibitory concentration: 670 nM
Compound 4: the middle estimate sits 2.2-fold (0.35 log units) above what was measured; low and high end bracket the measured number.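

In this assay, replacing 3-methylphenyl with 3-chlorophenyl on the core of compound 3 gives a 2.1-fold lower number from compound 3 to compound 4 (0.32 log units; beyond the scatter), so on this one core the chloro goes with modestly stronger inhibition. The same change on the core of compound 1 cannot be read, because compound 1 and compound 2 both give only a limit of the assay and no number: the limit of > 10000 nM in this assay, at which 2 of the 4 values shown sit. The series therefore offers a readable size for this change on one core only, and it neither shows that the gain carries over to the other core nor shows that it fails to do so.

As far as these compounds go, it remains open whether a nitrile, a methoxy group or an amine in the place held by the chloro would go further or lose the gain. From the compounds shown here alone, it is also open whether the step would keep its size on cores carrying a carboxylic acid or a longer chain on the amide.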